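Swapping methyl for methoxy on an aromatic carbon

A few compounds are considered here, and "the series" means these few. Any claim that something is new, unique, unknown or untested is made for them only; others in the source may bear on it.

Values so far in a functional assay on A2780 cells (Homo sapiens) for antiproliferative activity; on this read-out higher numbers stand for weaker inhibition and lower numbers for stronger inhibition
Compound 1 `CN(C)C(=O)N1Cc2c(F)cccc2C(c2cccc(O)c2)C1` result "not determined" (no result reported)
Compound 2 `CN(C)C(=O)N1Cc2c(Br)cccc2C(c2cccc(O)c2)C1` result "not determined" (no result reported)
Compound 3 `Cc1cccc2c1CN(C(=O)N(C)C)CC2c1cccc(O)c1` result 2050 nM

Neither of the other two compounds has a reported result. Among the compounds with values here, compound 3 holds the only number here. It therefore cannot yet be ranked against anything. The next compound to be tested, compound 4 `COc1cccc2c1CN(C(=O)N(C)C)CC2c1cccc(O)c1`, keeps the shared core and carries methoxy in place of methyl on an aromatic carbon. That carbon belongs to a six-membered aromatic ring of carbon only, part of a fused system of two rings.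

Within the data shown here, no two measured compounds differ in just one place, so the data give no guide to the size of such a change. With nothing pointing either way, no shift beyond the usual scatter is expected in this assay in either direction. This expectation rests on compound 3 at 2050 nM alone. The estimate amounts to a 1.0-fold lower number from compound 3 to compound 4 (0.01 log units; within the scatter) and carries a wide range. Compound 4 is expected at 2000 nM (estimated range 700 nM to 6000 nM).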

Compound 4, half-maximal inhibitory concentration: 332 nM
The estimate for compound 4 lay 6.0-fold (0.78 log units) above the measured number, and the stated range ends above it.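

In this assay, putting methoxy in place of methyl on this aromatic carbon gives a 6.2-fold lower number from compound 3 to compound 4 (0.79 log units; beyond the scatter) and so provides the first readable step: what this position carries matters, and here methoxy goes with stronger inhibition than methyl. The swap is small by count, with 2 heavy atoms entering for 1 and 1 hydrogen-bond acceptor added, yet the shift lies beyond the usual scatter. Nothing available explains why this swap gives stronger inhibition.

A single step cannot separate the contribution of the added oxygen from that of the added heavy atom. From the compounds shown here alone, it also remains open how an ethoxy group, an amine or a carboxylic acid on the same carbon would compare with methoxy.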